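A few compounds are considered here, and "the series" means these few. Any claim that something is new, unique, unknown or untested is made for them only; others in the source may bear on it.

Measured in a functional assay on P388 cells (Mus musculus) for cytotoxicity; on this read-out lower numbers stand for stronger inhibition and higher numbers for weaker inhibition:
compound 1 `COc1ccc(Cc2cn(C3CC3)c3c(F)c(-c4cc(C)nc(C)c4)c(F)cc3c2=O)cc1` gives 21000 nM
compound 2 `Cc1cc(-c2c(F)cc3c(=O)c(Cc4ccccc4)cn(C4CC4)c3c2F)cc(C)n1` gives 7300 nM
compound 3 `Cc1cc(-c2c(F)cc3c(=O)c(Cc4ccc(O)cc4O)cn(C4CC4)c3c2F)cc(C)n1` gives 210 nM

Compound 3 has the lowest number of the three, so it shows the strongest inhibition. Two large steps lead to it: a 100-fold lower number from compound 1 to compound 3 (2.00 log units; beyond the scatter) and a 35-fold lower number from compound 2 to compound 3 (1.54 log units; beyond the scatter). Both bring in the 2,4-dihydroxyphenyl group. The remaining step, a 2.9-fold lower number from compound 1 to compound 2 (0.46 log units; beyond the scatter), is modest.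

Compound 4 `Cc1cc(-c2c(F)cc3c(=O)c(Cc4ncc[nH]4)cn(C4CC4)c3c2F)cc(C)n1` changes one group of compound 3: 1H-imidazol-2-yl in place of 2,4-dihydroxyphenyl on a saturated chain carbon bound to an aromatic carbon. Here 1H-imidazol-2-yl replaces 2,4-dihydroxyphenyl on a saturated chain carbon bound to an aromatic carbon. Going by the values given here, no measured compound carries 1H-imidazol-2-yl, so any forecast is rough. The best guide is the large step of a 35-fold lower number from compound 2 to compound 3 (1.54 log units; beyond the scatter), read in reverse, since compound 4 also loses the 2,4-dihydroxyphenyl group. Part of that gain is expected to be lost, though perhaps not all of it. The expected change is a 9.5-fold higher number from compound 3 to compound 4 (0.98 log units; beyond the scatter), towards weaker inhibition. For compound 4 the estimated value is 2000 nM, with an expected range from 400 nM to 10000 nM.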

Compound 4, half-maximal inhibitory concentration: 1100 nM
Compound 4: the middle estimate sits 1.8-fold (0.26 log units) above what was measured; the range from low to high includes it.
By their numbers in this assay, from the lowest: compound 3; then compound 4; then compound 2; then compound 1.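

Until now, every group at this place, on a saturated chain carbon bound to an aromatic carbon, was a six-membered aromatic ring of carbon only. In this assay, a five-membered aromatic ring with 2 hetero atoms also gives a usable result, although swapping it in for 2,4-dihydroxyphenyl costs part of the best result, with a 5.2-fold higher number from compound 3 to compound 4 (0.72 log units; beyond the scatter), while the same group set against phenyl and 4-methoxyphenyl gives a 6.6-fold lower number from compound 2 to compound 4 (0.82 log units; beyond the scatter) and a 19-fold lower number from compound 1 to compound 4 (1.28 log units; beyond the scatter). So 2,4-dihydroxyphenyl is not the only group here that improves on phenyl, but nothing available explains this order.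

On these data alone, whether this place needs a ring at all stays open, and an amine or a carboxylic acid on the same chain carbon would test that. Also open, as far as these compounds go, is which hydroxyl of 2,4-dihydroxyphenyl matters, a question that 4-hydroxyphenyl and 2-hydroxyphenyl could separate.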